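This account rests on a few compounds, and the source may have more. Where it says the series, first, only, none or still open, it means among the compounds named here.

In a functional assay on the whole organism with Rattus norvegicus as the target (on this read-out higher numbers stand for an effect only at larger amounts of compound and lower numbers for an effect already at smaller amounts), compound 1 `CCCCNc1cccc(NC(=O)C(=O)OCC)c1C#N` gives 0.3 mg/kg, compound 2 `CCOC(=O)C(=O)Nc1cccc(N2CCCCC2)c1C#N` gives 2.2 mg/kg, and compound 3 `CCOC(=O)C(=O)Nc1cccc(OC(C)C)c1C#N` gives 2 mg/kg. Compound 3 therefore stands level with compound 2, and only compound 1 has a clearly lower number. Replacing butylamino produced modest steps: a 7.3-fold higher number from compound 1 to compound 2 (0.87 log units; beyond the scatter) and a 6.7-fold higher number from compound 1 to compound 3 (0.82 log units; beyond the scatter). Compound 4 `CCOC(=O)C(=O)Nc1cccc(C(=O)OC)c1C#N` carries methoxycarbonyl in place of isopropoxy on an aromatic carbon. Within the data shown here, no measured compound carries methoxycarbonyl, so the closest guide is the exchange of one butylamino-free group for another, a 1.1-fold lower number from compound 2 to compound 3 (0.04 log units; within the scatter). No step beyond the scatter is therefore expected in this assay. The expected step is a 1.3-fold higher number from compound 3 to compound 4 (0.10 log units; within the scatter). For compound 4 the estimated value is 2.5 mg/kg, with an expected range from 0.7 mg/kg to 8 mg/kg.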

Compound 4, dose for half-maximal effect: 1.2 mg/kg
The estimate for compound 4 lay 2.1-fold (0.32 log units) above the measured number; measured number inside the range.
By their numbers in this assay, from the lowest: compound 1; then compounds 4, 3 and 2 (each within the scatter of the next).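

In this assay, methoxycarbonyl on this aromatic carbon, ortho to a cyano group, stands level with both isopropoxy and piperidin-1-yl, with a 1.7-fold lower number from compound 3 to compound 4 (0.22 log units; within the scatter) and a 1.8-fold lower number from compound 2 to compound 4 (0.26 log units; within the scatter). Butylamino remains apart, with a 4.0-fold higher number from compound 1 to compound 4 (0.60 log units; beyond the scatter), so a third replacement of that group also gives a clearly higher number. Nothing available gives a reason for these numbers. From the compounds shown here alone, it remains open whether a smaller amine, such as methylamino, would keep the low number of compound 1. Going by these compounds, it is also open whether a carboxylic acid in place of methoxycarbonyl would stay level with compound 4.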